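Trading methylsulfonyl for bromo on the shared core

The source may report more compounds than this note shows. Statements on the series, on what has been measured and on what is new or still open speak of the compounds shown alone.

Compound 1 (`CN(C)/C(=N\C#N)C1=CC(C)(C)Oc2ccc(C#N)cc21`) gives 2140 nM in a functional assay on the whole organism for inhibition, with Cavia porcellus as the target (a lower number here means that less compound is needed, a higher number that more compound is needed for the effect), as its half-maximal effective concentration. Compound 2 (`CN(C)/C(=N\C#N)C1=CC(C)(C)Oc2ccc(S(C)(=O)=O)cc21`) differs from it in one place. Compound 2 reads > 31600 nM in this assay, which is a limit of the assay and not a number. So compound 2 has no exact value, only a bound.

Compound 3 (`CN(C)/C(=N\C#N)C1=CC(C)(C)Oc2ccc(Br)cc21`) has not yet been measured. Its change from compound 2 is bromo in place of methylsulfonyl on an aromatic carbon, which means bromo in place of methylsulfonyl on an aromatic carbon.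

For the measured compounds named here, only one measured step bears on this. Putting methylsulfonyl in place of cyano on that same carbon brought an at least 14-fold higher number from compound 1 to compound 2 (1.16 log units; beyond the scatter), a large change beyond the scatter. Compound 3 also gives up the methylsulfonyl, so a large move back towards a lower number is expected, though bromo is not cyano and the limit leaves the true size open. The estimated change is an at least 12-fold lower number from compound 2 to compound 3 (1.10 log units; beyond the scatter), and it is a rough one. For compound 3 the expected value is 2500 nM, with an estimated range from 500 nM to 15000 nM in this measure.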

Compound 3, half-maximal effective concentration: > 31600 nM
Compound 3 was reported as a limit; the forecaster's own chance of this, stated with the estimate: 10%; middle value at least 12-fold (1.10 log units) from the limit.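

In this assay, bromo in place of cyano on this aromatic carbon brings an at least 14-fold higher number from compound 1 to compound 3 (1.16 log units; beyond the scatter), a large step beyond the scatter. Until now, the loss of a readable value at this position was tied to methylsulfonyl alone, but it now also appears with bromo, a group of 1 heavy atom and 0 hydrogen-bond acceptors, against 4 heavy atoms and 2 hydrogen-bond acceptors for methylsulfonyl, so among these three compounds only compound 1, with its nitrile, gives a measured number. The step between compound 2 and compound 3 cannot be read, because both compounds stop at the same limit and neither has an exact value: the limit of > 31600 nM in this assay, at which 2 of the 3 values shown sit.

The compounds shown leave open whether any group other than the nitrile can give a readable value on this carbon, for example an amine, a carboxylic acid or a methoxy group. They also leave open how far compound 2 and compound 3 each lie beyond that limit, so the two cannot be placed in order.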